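Hydroxamic acid sulfonamides against histone deacetylase 11: a methoxy removed

A few compounds are considered here, and "the series" means these few. Any claim that something is new, unique, unknown or untested is made for them only; others in the source may bear on it.

Compound 1 `O=C(NO)c1ccc2c(c1)CCN(S(=O)(=O)c1cc(F)c(F)c(F)c1F)C2` – > 1000 nM
Compound 2 `COc1cc(C(=O)NO)ccc1CN(C(C)C)S(=O)(=O)c1cc(F)c(F)c(F)c1F` – > 1000 nM
Compound 3 `CC(C)N(Cc1ccc(C(=O)NO)cn1)S(=O)(=O)c1cc(F)c(F)c(F)c1F` – > 1000 nM

Of the compounds shown here, three have been tested in an assay on Sf9 cells for inhibition of histone deacetylase 11 (Homo sapiens), read by fluorescence and mobility shift assay; a higher number here means a weaker inhibitor, a lower number a stronger inhibitor. In this assay compound 1 gives > 1000 nM, which is a limit of the assay rather than a number. Compound 2 likewise reaches only > 1000 nM, again a limit. Compound 3 gives > 1000 nM, also a limit. For the measured compounds named here, none of the three sits at a measured number, so no step between measured compounds can be read; what is known is the limit of > 1000 nM in this assay, at which 3 of the 3 values shown sit. Compound 2 therefore stands at the same limit as the other two, and nothing separates it from them on the numbers shown.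

Compound 4 `CC(C)N(Cc1ccc(C(=O)NO)cc1)S(=O)(=O)c1cc(F)c(F)c(F)c1F` has not yet been measured in this assay. It differs from compound 2 in one place: hydrogen in place of methoxy on an aromatic carbon. The hydroxycarbamoyl group, the isopropyl-bearing sulfonamide and the tetrafluorophenyl part are unchanged.

Going by the values given here, with every measured compound at the limit and no measured step to lean on, no step beyond the scatter is expected from compound 2 to compound 4, so that a step that the limit leaves unreadable from compound 2 to compound 4 is the estimated step. Compound 4 is expected to give about 1500 nM in this assay, with a range from 500 nM to 5000 nM, and most likely only a limit will be reported again.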

Compound 4, half-maximal inhibitory concentration: > 1000 nM
Compound 4 gave a limit, no number; the forecaster's own chance of this, stated with the estimate: 75%; the middle value lies beyond the limit too.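

In this assay compound 4 gives > 1000 nM, a limit and not a number. Compound 2 also stands at a limit, so no step can be read between compound 2 and compound 4: the limit of > 1000 nM in this assay, at which 4 of the 4 values shown sit. The compounds shown leave open how strongly any of them inhibits, and whether hydrogen in place of methoxy changes that at all.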